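Three Hydroxyls Replace a Cyclopentyl on the Amide Nitrogen

The compounds below may be only part of what the source reports. "The series", "measured", "known", "first", "only" and "open" are said of these compounds alone.

Three compounds on a shared core, differing in the substituent on the amide-type nitrogen, have been measured. Compound 1 `COc1cccc2cc(C(=O)NC3CCCC3)c(=N)oc12` gives 20% in an assay on HeLa cells for displacement of a labelled ligand from adenosine receptor A3 (Homo sapiens), read by scintillation counting, with a stated time of 180 min, tested at 10 uM; on this read-out higher numbers stand for more inhibition at the one concentration tested (going by the name of the read-out) and lower numbers for less inhibition. Compound 2 `CCC(CO)NC(=O)c1cc2cc(Br)ccc2oc1=N` gives 24%, and compound 3 `N=c1oc2ccc(Br)cc2cc1C(=O)NCC(O)CO` gives 10%. Compound 1 stands second highest of the three numbers; its gap to compound 2 lies within the scatter, as does its gap to compound 3. Among the compounds with values here, the one step between measured compounds that differ in a single place is a number 14 percentage points lower from compound 2 to compound 3 (beyond the scatter), and it is the only step that bears on the change now in question. Compound 4 `COc1cccc2cc(C(=O)NC(CO)(CO)CO)c(=N)oc12` differs from compound 1 in this way: 2-hydroxy-1,1-bis(hydroxymethyl)ethyl in place of cyclopentyl on an amide-type nitrogen. Like the step from compound 2 to compound 3, this change brings additional hydroxyl groups onto the amide-type nitrogen substituent, and that earlier step was a modest fall beyond the scatter. The expectation for compound 4 is therefore a modest fall, a number 12 percentage points lower from compound 1 to compound 4 (beyond the scatter), with the size uncertain since the groups are not the same. Compound 4 is estimated at 8%, with a range from 0% to 20%.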

Compound 4, a percentage reported as inhibition, at one concentration (the size of the read-out at that concentration, not a potency): 18%
For compound 4 the middle estimate is 10 percentage points below the measured one, and the stated range covers the measured number.
By their numbers in this assay, from the lowest: compounds 3, 4, 1 and 2 (each within the scatter of the next, the first and the last beyond it).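

In this assay, putting 2-hydroxy-1,1-bis(hydroxymethyl)ethyl in place of cyclopentyl on the amide-type nitrogen gives a number 2 percentage points lower from compound 1 to compound 4 (within the scatter), so on the core of compound 1 this position accepts the open, hydroxyl-bearing group in place of the carbon ring with no difference the read-out can resolve. The earlier step, a number 14 percentage points lower from compound 2 to compound 3 (beyond the scatter), is not matched in this pair, so among the compounds shown, more hydroxyl groups on this substituent do not go with a lower number in every case. Nothing available explains why the two steps differ.

On these data alone, it remains open whether an amine or a carboxylic acid on this substituent would read differently on the core of compound 1. As far as these compounds go, it is also open whether 2-hydroxy-1,1-bis(hydroxymethyl)ethyl would give a similar number on the core of compound 2.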